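The compounds below may be only part of what the source reports. "The series", "measured", "known", "first", "only" and "open" are said of these compounds alone.

Measured so far in a functional assay for inhibition of sodium/hydrogen exchanger (Oryctolagus cuniculus); on this read-out higher numbers stand for weaker inhibition and lower numbers for stronger inhibition:

- compound 1, `CS(=O)(=O)c1cc(C(=O)N=C(N)N)c(Cl)cc1Cl`: 140 nM
- compound 2, `COc1cc(Cl)c(C(=O)N=C(N)N)cc1S(C)(=O)=O`: 40 nM
- compound 3, `COc1cc(N2CCC(N)CC2)c(S(C)(=O)=O)cc1C(=O)N=C(N)N`: 73 nM

Compound 2 and compound 1 differ in one place, (chloro in place of methoxy on an aromatic carbon), and this gives a 3.5-fold higher number from compound 2 to compound 1 (0.54 log units; beyond the scatter). Compound 3 sits with its value between the other two, and against both compound 2 and compound 1 the gaps are within the usual scatter, so no order among these three is claimed beyond the step from compound 2 to compound 1. The difference between the core of compound 3 and the core of compound 2 is not broken down here.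

Compound 4, `CS(=O)(=O)c1cc(C(=O)N=C(N)N)c(Cl)cc1N1CCC(N)CC1`, is not yet measured. It differs from compound 3 in one place, (chloro in place of methoxy on an aromatic carbon). Within the data shown here, this is the same kind of change as the one from compound 2 to compound 1, not the same change: in compound 1 the entering chloro stands ortho to a methylsulfonyl group, meta to a chloro group and para to a group of 6 heavy atoms, whereas in compound 4 it stands ortho to a group of 6 heavy atoms, meta to a 4-aminopiperidin-1-yl group and para to a methylsulfonyl group. Among the measured compounds shown here, only one earlier instance of this change exists, so the expectation rests on a single step.

For compound 4 in this assay a step of about a 3.0-fold higher number from compound 3 to compound 4 (0.48 log units; beyond the scatter) is expected, because compound 2 to compound 1 gave a 3.5-fold higher number from compound 2 to compound 1 (0.54 log units; beyond the scatter) and the surroundings of the change differ only as described. Compound 4 is therefore estimated at 220 nM, with a range from 90 nM to 550 nM.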

Compound 4, half-maximal inhibitory concentration: 20 nM
Estimate against measurement, compound 4: 11-fold (1.04 log units) above; the whole stated range lies above it.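

In this assay, chloro in place of methoxy does not carry from one core to the other, even in direction: the same change on two cores in this assay, a 3.5-fold higher number (0.54 log units; beyond the scatter) from compound 2 to compound 1 and a 3.7-fold lower number (0.56 log units; beyond the scatter) from compound 3 to compound 4, 13-fold (1.11 log units) apart, beyond the scatter of two such steps

On the core that holds the 4-aminopiperidin-1-yl group, this change gives a 3.7-fold lower number from compound 3 to compound 4 (0.56 log units; beyond the scatter) and runs opposite to the earlier step, so a step read on one core cannot be applied as a fixed increment to the other; two instances show that the outcome depends on the core, but they do not show which feature of the core decides it or what would hold across the wider series. Seen from the other side, 4-aminopiperidin-1-yl in place of chloro gives a 7.0-fold lower number from compound 1 to compound 4 (0.85 log units; beyond the scatter) and stands beyond the scatter, whereas 4-aminopiperidin-1-yl in place of methoxy gives a 2.0-fold lower number from compound 2 to compound 4 (0.30 log units; within the scatter) and stays within it, so only the first of these two replacements shows a clear difference.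

The compounds shown leave open whether the opposite direction is tied to the 4-aminopiperidin-1-yl group or would also appear with a dimethylamino group, a morpholine or a piperidine without the amine in that place. They also leave open whether fluoro or methyl in place of methoxy would follow the chloro step on either core.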